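The source may report more compounds than this note shows. Statements on the series, on what has been measured and on what is new or still open speak of the compounds shown alone.

In a functional assay on MGC-803 cells (Homo sapiens) for antiproliferative activity, read by MTT assay, with a stated time of 48 h (a higher number here means a weaker inhibitor, a lower number a stronger inhibitor), the measured compounds are:
Compound 1 (`COc1ccc(CN(C(=O)Cn2cc(CSc3nc4ccccc4o3)nn2)c2cc(OC)c(OC)c(OC)c2)cc1`) gives 1850 nM
Compound 2 (`COc1ccc(CN(C(=O)Cn2cc(CNS(=O)(=O)c3ccc(C)cc3)nn2)c2cc(OC)c(OC)c(OC)c2)cc1`) gives 1580 nM

Compound 2 stands level with compound 1 on these numbers (a 1.2-fold lower number from compound 1 to compound 2 (0.07 log units; within the scatter)). Compound 3 (`COc1ccc(CN(C(=O)Cn2cc(CNS(=O)(=O)c3ccc(Br)cc3)nn2)c2cc(OC)c(OC)c(OC)c2)cc1`) carries bromo in place of methyl on an aromatic carbon. Going by the values given here, no measured compound varies this position, so only that single step bears on the change, and it exchanged a whole group without leaving the scatter. No step beyond the scatter is therefore expected in this assay. The expected outcome is small (a 1.1-fold lower number from compound 2 to compound 3 (0.05 log units; within the scatter)). Compound 3 is estimated at 1400 nM with an expected range from 600 nM to 3300 nM.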

Compound 3, half-maximal inhibitory concentration: 430 nM
Compound 3: the middle estimate sits 3.3-fold (0.51 log units) above what was measured, and the stated range ends above it.
By their numbers in this assay, from the lowest: compound 3; then compounds 2 and 1 (each within the scatter of the next).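

In this assay, replacing methyl with bromo on the aromatic carbon para to a large group gives a 3.7-fold lower number from compound 2 to compound 3 (0.57 log units; beyond the scatter), so a change of one heavy atom at this position moves the number beyond the scatter. The ((4-bromophenyl)sulfonyl)amino group also separates from (1,3-benzoxazol-2-yl)sulfanyl, with a 4.3-fold lower number from compound 1 to compound 3 (0.63 log units; beyond the scatter), which the ((4-methylphenyl)sulfonyl)amino group did not do. No measurement here explains the gain seen with bromo. From the compounds shown here alone, whether chloro, methoxy or a carboxylic acid at this position would match bromo or methyl remains open.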